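The source may hold more compounds than are shown below. What is called first, only, known or untested is meant among the compounds shown, and "the series" means these compounds.

Compound 1 `COc1ccc([C@@H]2C/C(=N/OCc3cn(-c4ccc(C(=O)c5ccccc5)cc4)nn3)c3cc(CC=C(C)C)c(OC)cc3O2)cc1`: 34%
Compound 2 `COc1ccc([C@@H]2C/C(=N/OCc3cn(-c4ccc(C#N)cc4)nn3)c3cc(CC=C(C)C)c(OC)cc3O2)cc1`: 42%
Compound 3 `COc1ccc([C@@H]2C/C(=N/OCc3cn(-c4ccc(NC(=O)c5ccccc5)cc4)nn3)c3cc(CC=C(C)C)c(OC)cc3O2)cc1`: 31%

In a functional assay on A549 cells (Homo sapiens) for inhibition, read by sulforhodamine B assay, with a stated time of 48 h, tested at 50 uM (on this read-out lower numbers stand for less inhibition of growth and higher numbers for more inhibition of growth at the one concentration tested), compound 2 stands at 42%, level with compound 1 within the scatter, as a number 8 percentage points higher from compound 1 to compound 2 (within the scatter) shows, and clear of compound 3 only modestly, with a number 11 percentage points lower from compound 2 to compound 3 (beyond the scatter). The remaining measured step is a number 3 percentage points lower from compound 1 to compound 3 (within the scatter).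

Compound 4 `COc1ccc([C@@H]2C/C(=N/OCc3cn(-c4cccnc4Cl)nn3)c3cc(CC=C(C)C)c(OC)cc3O2)cc1` changes compound 2 as follows: 2-chloropyridin-3-yl in place of 4-cyanophenyl on an aromatic nitrogen. The measured steps bear on this only in part. Each swaps a group on an aromatic carbon, whereas here the whole group on the aromatic nitrogen changes. As those steps are small, no step beyond the scatter is expected in this assay, and no direction is firmly indicated. The expected change is a number 4 percentage points lower from compound 2 to compound 4 (within the scatter). Compound 4 is estimated at 38%, with an expected range of 26% to 50%.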

Compound 4, percent growth inhibition at one concentration: 58%
Compound 4: middle estimate off by 20 percentage points, on the low side; measured number outside the range, above it.
By their numbers in this assay, from the lowest: compounds 3, 1 and 2 (each within the scatter of the next, the first and the last beyond it); then compound 4.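

In this assay, the change to 2-chloropyridin-3-yl on the aromatic nitrogen gives a number 16 percentage points higher from compound 2 to compound 4 (beyond the scatter) and puts compound 4 above the other compounds. The earlier steps shown here swapped only a group on an aromatic carbon, and none of them raised the number above that of compound 2. Replacing the whole group on the aromatic nitrogen can therefore move this read-out upward, although nothing given here explains the rise.

The compounds shown do not separate the contribution of the ring nitrogen from that of the chlorine. A pyridin-3-yl group without chlorine and a 2-chlorophenyl group would each address that question.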